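A fluoro group added to compound 1

The compounds below may be only part of what the source reports. "The series", "measured", "known", "first", "only" and "open" are said of these compounds alone.

- compound 1 `O=C(/C=C\Nc1ccc(Cl)cc1)c1cn(-c2ccccc2)nc1-c1ccccc1`: 14100 nM
- compound 2 `O=C(/C=C\Nc1ccc(C(F)(F)F)cc1)c1cn(-c2ccccc2)nc1-c1ccccc1`: > 50000 nM (a limit of the assay)
- compound 3 `O=C(/C=C\Nc1ccc(O)cc1)c1cn(-c2ccccc2)nc1-c1ccccc1`: 3210 nM

In a functional assay on A549 cells (Homo sapiens) for antiproliferative activity, read by MTT assay, with a stated time of 48 h (on this read-out lower numbers stand for stronger inhibition and higher numbers for weaker inhibition), compound 1 gives 14100 nM, the higher of the two true numbers in this small series, and compound 3 holds the lower one. Compound 2 gives only a limit of the assay, > 50000 nM, and no number.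

Compound 4 `O=C(/C=C\Nc1ccc(Cl)cc1)c1cn(-c2ccccc2)nc1-c1ccc(F)cc1` keeps the core of compound 1 with one change: fluoro in place of hydrogen on an aromatic carbon. This turns a phenyl into a 4-fluorophenyl.

Within the data shown here, no measured step makes this change. The closest evidence comes from replacing the chloro of compound 1, which sits elsewhere in the molecule: an at least 3.5-fold higher number from compound 1 to compound 2 (0.54 log units; beyond the scatter) and a 4.4-fold lower number from compound 1 to compound 3 (0.64 log units; beyond the scatter). The widest gap is an at least 15-fold lower number from compound 2 to compound 3 (1.19 log units; beyond the scatter). These steps show that one substituent swap can move the number either way in this series, but they give no direction for a fluoro replacing a hydrogen. No step beyond the scatter is therefore expected, although a modest one of the size seen for compound 3 in a 4.4-fold lower number from compound 1 to compound 3 (0.64 log units; beyond the scatter) remains possible in either direction. The expected change is a 1.1-fold lower number from compound 1 to compound 4 (0.04 log units; within the scatter). For compound 4 the estimated value is 13000 nM, with an expected range from 5000 nM to 32000 nM.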

Compound 4, half-maximal inhibitory concentration: 6700 nM
The estimate for compound 4 lay 1.9-fold (0.29 log units) above the measured number; the measured number falls inside the stated range.
By their numbers in this assay, from the lowest: compound 3; then compound 4; then compound 1. At a limit, above all of these: compound 2.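

The earlier compounds shown here changed only the chloro, so they said nothing about the phenyl that becomes a 4-fluorophenyl in compound 4. In this assay, this place also proves responsive, with fluoro in place of hydrogen giving a 2.1-fold lower number from compound 1 to compound 4 (0.32 log units; beyond the scatter). A single added heavy atom is therefore enough to move the number beyond the scatter, and it moves in the same direction as the hydroxy swap at the chloro, which gave a 4.4-fold lower number from compound 1 to compound 3 (0.64 log units; beyond the scatter), and not in the direction of the trifluoromethyl swap. Nothing measured here gives a cause for this step.

The compounds shown leave open whether an amine, a methoxy group or a carboxylic acid at this place would lower the number further, raise it or leave it within the scatter, since fluoro is the only group seen here apart from hydrogen. They also leave open whether fluoro would give a step of similar size and direction on the core of compound 3, where hydroxy stands in place of the chloro.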